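Compound 4: trimming a methyl from compound 3

A few compounds are considered here, and "the series" means these few. Any claim that something is new, unique, unknown or untested is made for them only; others in the source may bear on it.

In a functional assay on the whole organism for inhibition of Polyunsaturated fatty acid 5-lipoxygenase (Mus musculus) (on this read-out higher numbers stand for an effect only at larger amounts of compound and lower numbers for an effect already at smaller amounts), three compounds have been measured:
Compound 1, `CC(=O)N(O)C(C)c1ccc2oc(-c3ccccc3)cc2c1`: 22.1 mg/kg
Compound 2, `CC(c1ccc2oc(-c3ccccc3)cc2c1)N(O)C(N)=O`: 10.3 mg/kg
Compound 3, `COCC(=O)N(O)C(C)c1ccc2oc(-c3ccccc3)cc2c1`: 18.6 mg/kg

Compound 3 stands within the scatter of compound 1, as shown by a 1.2-fold lower number from compound 1 to compound 3 (0.07 log units; within the scatter), and within the scatter of compound 2, as shown by a 1.8-fold higher number from compound 2 to compound 3 (0.26 log units; within the scatter); the one step beyond the scatter is a 2.1-fold lower number from compound 1 to compound 2 (0.33 log units; beyond the scatter). Compound 4, `CC(c1ccc2oc(-c3ccccc3)cc2c1)N(O)C(=O)CO`, differs from compound 3 by hydrogen in place of methyl on an oxygen on a saturated carbon. Going by the values given here, no measured pair removes a methyl from an oxygen, so the closest guide is the small step of a 1.2-fold lower number from compound 1 to compound 3 (0.07 log units; within the scatter) at the same chain carbon. The expected outcome in this assay is a 1.2-fold lower number from compound 3 to compound 4 (0.09 log units; within the scatter), not beyond the scatter. Compound 4 is estimated at 15 mg/kg, between 7 mg/kg and 35 mg/kg.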

Compound 4, dose for half-maximal effect: 27.5 mg/kg
Compound 4: middle estimate off by 1.8-fold (0.26 log units), on the low side; the range from low to high includes it.
By their numbers in this assay, from the lowest: compounds 2, 3, 1 and 4 (each within the scatter of the next, the first and the last beyond it).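

In this assay, hydrogen in place of methyl on the oxygen stays within the scatter (with a 1.5-fold higher number from compound 3 to compound 4 (0.17 log units; within the scatter)), and so does hydroxy in place of hydrogen on the saturated chain carbon (with a 1.2-fold higher number from compound 1 to compound 4 (0.09 log units; within the scatter)), so hydrogen, methoxy and hydroxy at this chain carbon cannot be told apart here. Hydroxymethyl in place of amino on the carbonyl carbon, by contrast, goes beyond the scatter (with a 2.7-fold higher number from compound 2 to compound 4 (0.43 log units; beyond the scatter)). No measurement shown bears on why these steps have this size. Still open, going by these compounds, is whether an amine or a carboxylic acid at this chain carbon, or a longer chain on the carbonyl carbon, would also stay within the scatter.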